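The source may hold more compounds than are shown below. What is called first, only, known or untested is meant among the compounds shown, and "the series" means these compounds.

For the measured compounds named here, compound 1 `Cc1oc(-c2c(Br)cccc2Br)nc1CN1CCC(C(=O)NCCCN2C[C@H](C)C[C@H](C)C2)CC1` is the only compound here with a plain number from an ADME assay on microsomes from liver (Rattus norvegicus) for metabolic stability, read by LC-MS, using NADPH, at 37 degrees C (on this read-out higher numbers stand for a longer-lived compound and lower numbers for a shorter-lived compound), and in this assay compound 1 gives 0.035 h, a very short half-life. Compound 2 `Cc1ccccc1-c1nc(CN2CCC(C(=O)N3CCN(C4CCN(C)CC4)CC3)CC2)c(C)o1` carries a different amine at one end of the shared core, and in this assay compound 2 reaches > 0.5 h, which is a limit of the assay rather than a number (the limit of > 0.5 h in this assay, at which 1 of the 2 values shown sits). Compound 3 `COc1ccc(-c2nc(CN3CCC(C(=O)NCCCN4C[C@H](C)C[C@H](C)C4)CC3)c(C)o2)cc1OC` has not yet been measured. It differs from compound 1 in one place: 3,4-dimethoxyphenyl in place of 2,6-dibromophenyl on an aromatic carbon. Going by the values given here, no step between two measured compounds is available to guide this change, so its effect in this assay remains open. Because compound 1 gives 0.035 h and compound 3 keeps the rest of that structure, the expected step is a 1.4-fold higher number from compound 1 to compound 3 (0.15 log units; within the scatter), within the usual scatter. The half-life of compound 3 in this assay is estimated at 0.05 h, ranging from 0.02 h to 0.15 h.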

Compound 3, half-life: > 0.5 h
Compound 3 gave a limit, no number; the forecaster's own chance of this, stated with the estimate: 5%; middle value at least 10-fold (1.00 log units) from the limit.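

For the compounds shown here, replacing 2,6-dibromophenyl with 3,4-dimethoxyphenyl on this aromatic carbon, with the rest of compound 1 kept, gives the first step that can be read at this position in this assay, and it is large: an at least 14-fold higher number from compound 1 to compound 3 (1.15 log units; beyond the scatter). This shows that a change in this one place can move the half-life beyond the scatter, which compound 2 could not show, as it differs from compound 1 in more than one place. Going by these compounds, the value of compound 3 is a limit and not a number, so the real size of the step stays unknown, and compound 3 cannot be ranked against compound 2: the limit of > 0.5 h in this assay, at which 2 of the 3 values shown sit.

The compounds shown leave open whether the loss of the two bromines or the arrival of the two methoxy groups matters more. Unsubstituted phenyl or a phenyl carrying one methoxy group, on the same core, would help separate the two.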